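The source may hold more compounds than are shown below. What is called first, only, known or untested is meant among the compounds shown, and "the series" means these compounds.

In a functional assay on the whole organism (strain Wistar) for inhibition, with Rattus norvegicus as the target, read by paw edema, with a stated time of 1 h, at a dose of 10 mg/kg by the intraperitoneal route (on this read-out lower numbers stand for less inhibition and higher numbers for more inhibition at the one dose given (going by the name of the read-out)), compound 1 `O=C(N/N=C/c1cccnc1)c1cccnc1Nc1cccc(C(F)(F)F)c1` gives 76.1%. Compound 2 `O=C(N/N=C/c1ccncc1)c1cccnc1Nc1cccc(C(F)(F)F)c1` carries pyridin-4-yl in place of pyridin-3-yl on a carbon with a double bond to nitrogen, and in this assay compound 2 gives 70.2%, so that the step of a number 5.9 percentage points lower from compound 1 to compound 2 (within the scatter) is small. Compound 3 `CNc1ncccc1C(=O)N/N=C/c1cccnc1` has a different core; how its core differs from that of compound 1 is not broken down here. In this assay compound 3 gives 61.1%. Compound 4 `CNc1ncccc1C(=O)N/N=C/c1ccncc1`, not yet measured, carries the same change, (pyridin-4-yl in place of pyridin-3-yl on a carbon with a double bond to nitrogen), made on the core of compound 3. Because the earlier step of a number 5.9 percentage points lower from compound 1 to compound 2 (within the scatter) stayed within the usual scatter, the step for compound 4 is expected to be of similar size, a number 5.1 percentage points lower from compound 3 to compound 4 (within the scatter). Compound 4 is therefore estimated at 56%, with a likely range from 42% to 68%.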

Compound 4, a percentage reported as inhibition, in the whole organism at one dose (the size of the read-out at that dose, not a potency): 80.4%
Beside the measured number, compound 4's estimate is 24.4 percentage points below it; the measured number lies above the stated range.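

In this assay the swap of pyridin-3-yl for pyridin-4-yl gives a number 19.3 percentage points higher from compound 3 to compound 4 (beyond the scatter), and the same swap does not give the same result on the two cores: the same change on two cores in this assay, a number 5.9 percentage points lower (within the scatter) from compound 1 to compound 2 and a number 19.3 percentage points higher (beyond the scatter) from compound 3 to compound 4, 25.2 percentage points apart, beyond the scatter of two such steps.
So, in this series, the step seen on one core could not simply be carried over to the other. These two pairs do not show why the cores differ, and they give no rule for predicting the step on any further core.

The compounds shown leave open how a pyridin-2-yl group would compare on the same carbon with a double bond to nitrogen. They also leave open which step would appear on a core with a longer chain, such as butyl, in place of the methyl group of compound 3.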